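From compound 2 to compound 4: chloro for methoxy

The source may hold more compounds than are shown below. What is called first, only, known or untested is meant among the compounds shown, and "the series" means these compounds.

Measured in an ADME assay on KB cells (Homo sapiens) for cytotoxicity; on this read-out higher numbers stand for an effect only at larger amounts of compound and lower numbers for an effect already at smaller amounts:
Compound 1 `COc1cc2c(c(OCc3ccccc3)c1OC)C(=O)[C@]1(OC)C=C[C@H]2N(C(=O)OCC(C)C)N1C(=O)OCC(C)C`: 94 ug/mL
Compound 2 `COC(=O)N1[C@@H]2C=C[C@@](OC)(C(=O)c3c2cc(OC)c(OC)c3OCc2ccc(OC)cc2)N1C(=O)OC`: > 300 ug/mL (a limit)
Compound 3 `CCOC(=O)N1[C@@H]2C=C[C@@](OC)(C(=O)c3c2cc(OC)c(OC)c3OCc2ccccc2F)N1C(=O)OCC`: 99.7 ug/mL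

Compound 2 stands at > 300 ug/mL, which is a limit of the assay and not a number. Compound 4 `COC(=O)N1[C@@H]2C=C[C@@](OC)(C(=O)c3c2cc(OC)c(OC)c3OCc2ccc(Cl)cc2)N1C(=O)OC` differs from it by chloro in place of methoxy on an aromatic carbon, with chloro in place of methoxy on an aromatic carbon, para to a large group. Among the measured compounds shown here, no measured step between compounds differing in one place is available. Compound 1 gives 94 ug/mL and compound 3 gives 99.7 ug/mL, within the usual scatter of each other, so a moderate move toward lower numbers in this assay is expected. The expected size is an at least 1.8-fold lower number from compound 2 to compound 4 (0.27 log units; that floor lies within the scatter). For compound 4 the estimate is 160 ug/mL, with an expected range of 60 ug/mL to 400 ug/mL.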

Compound 4, concentration for half-maximal effect: 55.9 ug/mL
Compound 4: the middle estimate sits 2.9-fold (0.46 log units) above what was measured, and the stated range ends above it.
By their numbers in this assay, from the lowest: compounds 4, 1 and 3 (each within the scatter of the next). At a limit, above all of these: compound 2.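

In this assay, compound 2, with its 4-methoxybenzyl group, stands at a limit and not a number: > 300 ug/mL. Chloro in place of methoxy on this aromatic carbon gives an at least 5.3-fold lower number from compound 2 to compound 4 (0.72 log units; beyond the scatter), the only step here between compounds that differ in one place. Its full size cannot be read, as it starts from a limit: the limit of > 300 ug/mL in this assay, at which 1 of the 4 values shown sits.

Open, from the compounds shown here alone, is whether this lower number is particular to chloro or also follows from other replacements of methoxy at this place. A nitrile or an amine on the same aromatic carbon would test this.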